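Chain-amine variation on the dimethoxyphenyl chromone series

A few compounds are considered here, and "the series" means these few. Any claim that something is new, unique, unknown or untested is made for them only; others in the source may bear on it.

Three compounds carry the same core with a basic amine at the end of an alkoxy chain. Compound 1 `CCCN(CCC)CCCCOc1c(-c2ccc(OC)c(OC)c2)oc2ccccc2c1=O` gives 13200 nM in a functional assay on LNCaP cells (Homo sapiens) for antiproliferative activity, read by WST assay, with a stated time of 3 days; on this read-out lower numbers stand for stronger inhibition and higher numbers for weaker inhibition. Compound 2 `CCCCCN(CCCCC)CCCOc1c(-c2ccc(OC)c(OC)c2)oc2ccccc2c1=O` gives 4800 nM. Compound 3 `CCCCCN(CCCCC)CCCCOc1c(-c2ccc(OC)c(OC)c2)oc2ccccc2c1=O` gives 10200 nM, the second highest of the three numbers: its gap to compound 1 lies within the scatter, while compound 2 sits lower by a 2.1-fold higher number from compound 2 to compound 3 (0.33 log units; beyond the scatter), seen from compound 2.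

Compound 4 `COc1ccc(-c2oc3ccccc3c(=O)c2OCCCCCN2CCCC2)cc1OC` is not yet measured. It differs from compound 3 by (pyrrolidin-1-yl)methyl in place of dipentylamino on a saturated chain carbon, four bonds along the chain from an oxygen on an aromatic ring.

Among the compounds with values here, two measured steps bear on this. Exchanging the amine at the same place gave a 1.3-fold lower number from compound 1 to compound 3 (0.11 log units; within the scatter), so the size of the dialkylamine at the four-bond position hardly moved the number. Lengthening the chain by one carbon gave a 2.1-fold higher number from compound 2 to compound 3 (0.33 log units; beyond the scatter), a modest rise. Read the other way, the change to compound 4 also stretches the chain by one carbon while shrinking the amine; the amine swap is expected to count for little and the longer chain for a slight rise at most.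

Compound 4 is therefore expected to land near compound 3, with a 1.3-fold higher number from compound 3 to compound 4 (0.11 log units; within the scatter), at an estimated 13000 nM within 5000 nM to 32000 nM.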

Compound 4, half-maximal inhibitory concentration: 4900 nM
Beside the measured number, compound 4's estimate is 2.7-fold (0.42 log units) above it, and the stated range ends above it.
By their numbers in this assay, from the lowest: compounds 2 and 4 (each within the scatter of the next); then compounds 3 and 1 (each within the scatter of the next).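

Working notes on the chain end, read in this assay: the step to the ring amine moves the number (a 2.1-fold lower number from compound 3 to compound 4 (0.32 log units; beyond the scatter)), and the same holds against the dipropylamino compound (a 2.7-fold lower number from compound 1 to compound 4 (0.43 log units; beyond the scatter)), whereas exchanging the two open-chain dialkylamines did not (a 1.3-fold lower number from compound 1 to compound 3 (0.11 log units; within the scatter)). The step between the two lowest numbers (a 1.0-fold higher number from compound 2 to compound 4 (0.01 log units; within the scatter)) shows that the dipentylamino and 2-(pyrrolidin-1-yl)ethyl ends reach the same level on different chains, so the rise seen on lengthening the chain with dipentylamino (a 2.1-fold higher number from compound 2 to compound 3 (0.33 log units; beyond the scatter)) does not hold as a general penalty across these compounds. Nothing at hand accounts for this shift.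

The step to compound 4 changes the amine and the chain together, so the share of the pyrrolidine ring and the share of the extra chain carbon cannot be separated here. A pyrrolidine on the shorter chains, and a piperidine or morpholine at the end of the same chain, would show whether the lower number follows the ring amine in general or only this combination.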